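A few compounds are considered here, and "the series" means these few. Any claim that something is new, unique, unknown or untested is made for them only; others in the source may bear on it.

Measured compounds:
- compound 1 `CN1CCN(c2ccc(Nc3ncc4nc(Nc5ccc(F)cc5)n(-c5cccc(NC(=O)CO)c5)c4n3)cc2)CC1`: 1670 nM
- compound 2 `CN1CCN(c2ccc(Nc3ncc4nc(Nc5ccccc5)n([C@@H]5CCNC5)c4n3)cc2)CC1`: "not determined" (no result reported)
- compound 3 `CC(=O)N1CC[C@H](n2c(Nc3ccccc3)nc3cnc(Nc4ccc(N5CCN(C)CC5)cc4)nc32)C1`: "not determined" (no result reported)

Among the compounds with values here, compound 1 is the only member of this set with a number in a functional assay on A-431 cells (Homo sapiens) for antiproliferative activity, read by MTT assay, with a stated time of 72 h; on this read-out lower numbers stand for stronger inhibition and higher numbers for weaker inhibition: there compound 1 gives 1670 nM. Compound 2 and compound 3, both of which carry a pyrrolidin-3-yl group on the same aromatic nitrogen of the shared core, were not measured, so no comparison of values within the set is possible.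

Compound 4 `CN1CCN(c2ccc(Nc3ncc4nc(Nc5ccc(F)cc5)n([C@H]5CCN(S(=O)(=O)C6CC6)C5)c4n3)cc2)CC1` differs from compound 1 in one place: 1-(cyclopropylsulfonyl)pyrrolidin-3-yl in place of 3-(((hydroxymethyl)carbonyl)amino)phenyl on an aromatic nitrogen. The group that leaves is aromatic and holds two hydrogen-bond donors; the group that enters is non-aromatic, carries no donor, and brings a defined stereocentre. Within the data shown here, since no step between measured compounds exists, there is nothing within the data to say how such an exchange moves the read-out; the expectation for compound 4 rests on compound 1 alone and on the size of the change. A step of modest size toward stronger inhibition is expected, a 1.9-fold lower number from compound 1 to compound 4 (0.27 log units; within the scatter), but a result within the scatter of compound 1 cannot be excluded. Compound 4 is therefore estimated at 900 nM in this assay, with a range from 250 nM to 3500 nM.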

Compound 4, half-maximal inhibitory concentration: 1670 nM
Beside the measured number, compound 4's estimate is 1.9-fold (0.27 log units) below it; the range from low to high includes it.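

In this assay, within the data shown here, replacing 3-(((hydroxymethyl)carbonyl)amino)phenyl with 1-(cyclopropylsulfonyl)pyrrolidin-3-yl on the aromatic nitrogen gives no change at the digits printed from compound 1 to compound 4 (within the scatter), the first step that can be read at this position. The entering group has no aromatic ring and no hydrogen-bond donor, and it brings a defined stereocentre, so for this pair neither the six-membered aromatic ring nor the donors of the leaving group are needed to keep the read-out where it stands. Both groups hold 11 heavy atoms, so this step shows an exchange of ring type and donors at equal heavy-atom count, and it says nothing about a change in size.

Going by these compounds, it remains open whether a methylsulfonyl or benzenesulfonyl group on the pyrrolidine nitrogen, or a piperidin-4-yl ring in place of the pyrrolidine, would keep the read-out in this assay within the scatter or move it beyond. On these data alone, the opposite configuration at the stereocentre of the pyrrolidine and a carboxylic acid on the phenyl ring of compound 1 are equally open. Nothing given here offers a reason for this outcome.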